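Swapping Bromo for Methoxy on a Second Core

A few compounds are considered here, and "the series" means these few. Any claim that something is new, unique, unknown or untested is made for them only; others in the source may bear on it.

Of the compounds shown here, three have been tested in a functional assay on HT-29 cells (Homo sapiens) for antiproliferative activity, read by MTT assay, with a stated time of 72 h; on this read-out higher numbers stand for weaker inhibition and lower numbers for stronger inhibition. Compound 1 `O=C(Nc1ccc(Oc2ccnc3[nH]ccc23)c(F)c1)c1cc2cccnc2n(-c2ccc(Br)cc2)c1=O` gives 120 nM. Compound 2 `COc1ccc(-n2c(=O)c(C(=O)Nc3ccc(Oc4ccnc5[nH]ccc45)c(F)c3)cc3cccnc32)cc1` carries the change (methoxy in place of bromo on an aromatic carbon), and in this assay compound 2 gives 540 nM; the step is a 4.5-fold higher number from compound 1 to compound 2 (0.65 log units; beyond the scatter). Compound 3 `Cn1ccc2c(Oc3ccc(NC(=O)c4cc5cccnc5n(-c5ccc(Br)cc5)c4=O)cc3)ccnc21` rests on a different core; the difference between the two cores is not broken down here. In this assay compound 3 gives 690 nM, a number close to that of compound 2 and clearly higher than that of compound 1.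

Compound 4 `COc1ccc(-n2c(=O)c(C(=O)Nc3ccc(Oc4ccnc5c4ccn5C)cc3)cc3cccnc32)cc1` is not yet measured. It differs from compound 3 by methoxy in place of bromo on an aromatic carbon, the same change that separates compound 1 from compound 2, made at the same place. The expectation for compound 4 therefore rests on that one earlier step: the move from compound 3 to compound 4 is estimated as a 4.1-fold higher number from compound 3 to compound 4 (0.61 log units; beyond the scatter), in the same direction and of about the same size as the step from compound 1 to compound 2. On this basis compound 4 is expected to give about 2800 nM in this assay, estimated to fall between 1000 nM and 7500 nM.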

Compound 4, half-maximal inhibitory concentration: 2050 nM
The estimate for compound 4 lay 1.4-fold (0.14 log units) above the measured number; the measured number falls inside the stated range.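

In this assay, methoxy in place of bromo again gives weaker inhibition, with a 3.0-fold higher number from compound 3 to compound 4 (0.47 log units; beyond the scatter). The change therefore carries over from one core to the other in direction, and the two steps are no further apart than repeated measurements could explain: the same change on two cores in this assay, a 4.5-fold higher number (0.65 log units; beyond the scatter) from compound 1 to compound 2 and a 3.0-fold higher number (0.47 log units; beyond the scatter) from compound 3 to compound 4, 1.5-fold (0.18 log units) apart, within the scatter of two such steps. For the compounds shown here, this shows that going from 4-bromophenyl to 4-methoxyphenyl behaves alike on these two cores, but with only one pair on each core it does not show that the same step would hold on a third core, nor does it explain why inhibition weakens.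

The compounds shown leave open whether the difference comes from losing the bromo or from gaining the methoxy, and a plain phenyl, a 4-chlorophenyl or a 4-methylphenyl group at the same place could help separate the two. Also open, going by these compounds, is how a larger change at that place, such as an amine or a carboxylic acid, would compare on either core.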